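Carboxy in Place of Methoxy: Expected Potency of Compound 3

The source may report more compounds than this note shows. Statements on the series, on what has been measured and on what is new or still open speak of the compounds shown alone.

Of the compounds shown here, two of a shared core have been measured in an assay on isolated protein for inhibition of protein deacetylase HDAC6 (Homo sapiens); a lower number here means a stronger inhibitor, a higher number a weaker inhibitor. Compound 1 `COc1ccc(-c2ccc(C(=O)C(F)(F)F)s2)cc1` gives only a limit, > 1000 nM. Its standing in this assay is thus known only as the limit of > 1000 nM in this assay, at which 1 of the 2 values shown sits. Compound 2 `COc1ccccc1-c1ccc(C(=O)C(F)(F)F)s1` gives 6300 nM. Compound 3 `O=C(O)c1ccc(-c2ccc(C(=O)C(F)(F)F)s2)cc1` differs from compound 1 by carboxy in place of methoxy on an aromatic carbon. Going by the values given here, no measured step of this kind is at hand, and no shift beyond the usual scatter is expected, so the estimated step is a step that the limit leaves unreadable from compound 1 to compound 3. Compound 3 is therefore expected to give about 5000 nM, with a range from 1200 nM to 30000 nM.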

Compound 3, half-maximal inhibitory concentration: 27 nM
The estimate for compound 3 lay 190-fold (2.27 log units) above the measured number, outside the stated range (below it).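

In this assay, carboxy in place of methoxy on an aromatic carbon, para to a large group, gives an at least 37-fold lower number from compound 1 to compound 3 (1.56 log units; beyond the scatter), a large step beyond the scatter. This shows that the group at this position can strongly change the potency of the shared core, which the two methoxy compounds could not reveal. The true size of the step remains unknown because compound 1 stands at a limit, not at a number: the limit of > 1000 nM in this assay, at which 1 of the 3 values shown sits.

From the compounds shown here alone, whether a methyl ester, a primary amide or an amine at this position would also lower the number remains open. So does whether carboxy elsewhere on the six-membered ring would have the same effect.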